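Carboxy for Chloro on the Aryl Ring of Compound 3

The compounds below may be only part of what the source reports. "The series", "measured", "known", "first", "only" and "open" are said of these compounds alone.

Of the compounds shown here, three have so far been tested in a functional assay on the whole organism for inhibition, with Rattus norvegicus as the target; on this read-out lower numbers stand for an effect already at smaller amounts and higher numbers for an effect only at larger amounts of compound. Compound 1 `CC1CC/C(=N\Nc2ccccc2)c2ncc(CC(=O)O)c(=O)n21` gives 100 umol/kg, and compound 2 `O=C(O)c1cnc2n(c1=O)CCC/C2=N\Nc1ccccc1` gives 31.6 umol/kg. Compound 3 `CC1CC/C(=N\Nc2ccc(Cl)cc2)c2ncc(C(=O)O)c(=O)n21` gives 0.5 umol/kg, the lowest number of the three and beyond the scatter from both others. Compound 4 `CC1CC/C(=N\Nc2ccc(C(=O)O)cc2)c2ncc(C(=O)O)c(=O)n21` differs from compound 3 in one place: carboxy in place of chloro on an aromatic carbon. Among the compounds with values here, no pair of measured compounds differs in exactly this way, so the size of the step has no direct precedent here. Because compound 3 stands at 0.5 umol/kg, a moderate step toward higher numbers beyond the scatter is expected. Compound 4 is estimated at 2 umol/kg, within 0.4 umol/kg to 10 umol/kg. The expected step in this assay is a 4.0-fold higher number from compound 3 to compound 4 (0.60 log units; beyond the scatter).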

Compound 4, dose for 50% inhibition: 7.6 umol/kg
Compound 4: the middle estimate sits 3.8-fold (0.58 log units) below what was measured, and the stated range covers the measured number.
By their numbers in this assay, from the lowest: compound 3; then compound 4; then compound 2; then compound 1.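

In this assay, the aromatic carbon para to a large group proves sensitive to what it carries: carboxy in place of chloro gives a 15-fold higher number from compound 3 to compound 4 (1.18 log units; beyond the scatter) and this large step lies beyond the scatter. Within the data shown here, this is the first step read at this position, as the earlier compounds offered no pair differing in one place. Nothing measured here explains why the number rises with this change. Going by these compounds, whether an amine or a methoxy group on this same carbon would stay closer to chloro or to carboxy remains open. So does whether a methyl ester of the carboxy group would recover the lower number of compound 3 0.5 umol/kg in this assay.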